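The source may report more compounds than this note shows. Statements on the series, on what has been measured and on what is new or still open speak of the compounds shown alone.

Measured compounds in a functional assay on HepG2 cells (Homo sapiens) for cytotoxicity, read by MTT assay, with a stated time of 48 h; a higher number here means a weaker inhibitor, a lower number a stronger inhibitor:
compound 1, `O=C(CSc1nnc(-c2ccncc2)o1)N/N=C/c1ccc(Cl)cc1`: 15700 nM
compound 2, `O=C(CSc1nnc(-c2ccncc2)o1)N/N=C/c1ccc([N+](=O)[O-])cc1`: 17900 nM
compound 3, `COc1cc(/C=N/NC(=O)CSc2nnc(-c3ccncc3)o2)ccc1O`: 2920 nM

Compound 2 holds the highest of the three numbers. Its nearest neighbour is compound 1, with a 1.1-fold higher number from compound 1 to compound 2 (0.06 log units; within the scatter); its furthest is compound 3, with a 6.1-fold lower number from compound 2 to compound 3 (0.79 log units; beyond the scatter).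

Compound 4, `O=C(CSc1nnc(-c2ccncc2)o1)N/N=C/c1cccs1`, is not yet measured. It differs from compound 2 in one place: thiophen-2-yl in place of 4-nitrophenyl on a carbon with a double bond to nitrogen.

All three measured steps concern the group on the carbon with a double bond to nitrogen, so all bear on this change, though none swaps the six-membered ring for a five-membered one. Between chloro and nitro the number hardly moves, a 1.1-fold higher number from compound 1 to compound 2 (0.06 log units; within the scatter). Going to 4-hydroxy-3-methoxyphenyl lowers it modestly in both cases, a 5.4-fold lower number from compound 1 to compound 3 (0.73 log units; beyond the scatter) and a 6.1-fold lower number from compound 2 to compound 3 (0.79 log units; beyond the scatter). Among the measured compounds shown here, the series thus shows this position can shift the read-out by a modest amount, but gives no direct precedent for thiophen-2-yl.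

Compound 4 is therefore expected to land between the two ends seen so far, with a wide range: 9000 nM, from 3000 nM to 27000 nM. The estimated step from compound 2 is a 2.0-fold lower number from compound 2 to compound 4 (0.30 log units; within the scatter), expected to be no more than modest in the lowering direction.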

Compound 4, half-maximal inhibitory concentration: 14900 nM
Compound 4: middle estimate off by 1.7-fold (0.22 log units), on the low side; the measured number falls inside the stated range.
By their numbers in this assay, from the lowest: compound 3; then compounds 4, 1 and 2 (each within the scatter of the next).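

In this assay, thiophen-2-yl is the only five-membered aromatic ring shown on the carbon with a double bond to nitrogen, and it cannot be told apart from the two para-free comparators, 4-nitrophenyl with a 1.2-fold lower number from compound 2 to compound 4 (0.08 log units; within the scatter) and 4-chlorophenyl with a 1.1-fold lower number from compound 1 to compound 4 (0.02 log units; within the scatter). Across compounds 1, 2 and 4, replacing the six-membered ring with the smaller five-membered ring therefore gives no separable change in the read-out, whereas 4-hydroxy-3-methoxyphenyl remains the one group that stands apart, with a 5.1-fold higher number from compound 3 to compound 4 (0.71 log units; beyond the scatter). Nothing available accounts for the separation of compound 3 from the other three compounds.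

The hydroxy and methoxy groups occur together only in compound 3, leaving open whether the lower number follows one of them or needs both; 4-hydroxyphenyl and 4-methoxyphenyl at this place would address that directly. From the compounds shown here alone, it also remains open whether the flat read-out of compounds 1, 2 and 4 extends to other groups at this place, such as 4-aminophenyl, furan-2-yl or a cyclohexyl ring.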